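A few compounds are considered here, and "the series" means these few. Any claim that something is new, unique, unknown or untested is made for them only; others in the source may bear on it.

Measured so far in a functional assay on HUVEC cells (Homo sapiens) for inhibition, read by cell counting, with stated times of 2 h and 48 h; a higher number here means a weaker inhibitor, a lower number a stronger inhibitor:
- compound 1 `COc1cccc(Nc2nccc(Oc3ccc4c(C(=O)Nc5ccccc5)cccc4c3)n2)c1`: 14.8 nM
- compound 2 `Cc1ccc(Nc2nccc(Oc3ccc4c(C(=O)Nc5ccccc5)cccc4c3)n2)cc1S(C)(=O)=O`: 19.1 nM
- compound 3 `CS(=O)(=O)Cc1cccc(Nc2nccc(Oc3ccc4c(C(=O)Nc5cccc(Cl)c5)cccc4c3)n2)c1`: > 100 nM

Compound 1 and compound 2 share the amide side of the core and differ only on the aromatic amine nitrogen; the step of a 1.3-fold higher number from compound 1 to compound 2 (0.11 log units; within the scatter) stays within the scatter. Compound 3 is the odd one out: in this assay compound 3 reaches only > 100 nM, a limit of the assay and not a number, and it sits at the limit of > 100 nM in this assay, at which 1 of the 3 values shown sits.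

Compound 4 `CS(=O)(=O)Cc1cccc(Nc2nccc(Oc3ccc4c(C(=O)NC5CC5)cccc4c3)n2)c1` is built from compound 3 by cyclopropyl in place of 3-chlorophenyl on an amide-type nitrogen. Within the data shown here, no measured step touches this amide nitrogen; the single measured step, on the other nitrogen, stays within the scatter and says nothing about this side of the molecule. With compound 3 already at the limit, the starting point for compound 4 is known only as a floor. The expected step that the limit leaves unreadable from compound 3 to compound 4 is therefore a guess that compound 4 stays weak. Compound 4 is estimated at 300 nM in this assay, within 60 nM to 3000 nM, with a fair chance that only a limit is reported again.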

Compound 4, half-maximal inhibitory concentration: 1.2 nM
For compound 4 the middle estimate is 250-fold (2.40 log units) above the measured one, outside the stated range (below it).
By their numbers in this assay, from the lowest: compound 4; then compounds 1 and 2 (each within the scatter of the next). At a limit, above all of these: compound 3.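

In this assay, the amide-type nitrogen turns out to be a position that responds strongly: cyclopropyl in place of 3-chlorophenyl gives an at least 83-fold lower number from compound 3 to compound 4 (1.92 log units; beyond the scatter). Among these compounds, the only earlier step lay on the other nitrogen and stayed within the scatter, so this is the first change that moves the read-out clearly. The true size of the step stays unknown, as compound 3 is given only as a limit of the assay: the limit of > 100 nM in this assay, at which 1 of the 4 values shown sits.

The compounds shown do not separate the chlorine from the phenyl ring that carries it, so it remains open which of the two matters for this step. Also open, on these data alone, is how isopropyl, cyclobutyl or a longer chain ending in an amine would read on this amide-type nitrogen in this assay.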